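The source may hold more compounds than are shown below. What is called first, only, known or untested is meant among the compounds shown, and "the series" means these compounds.

Measured so far in a functional assay on A549 cells (Homo sapiens) for cytotoxicity, read by sulforhodamine B assay; on this read-out higher numbers stand for weaker inhibition and lower numbers for stronger inhibition:

compound 1 `COc1ccc([C@H]2O[C@H](c3cc(OC)c(OC)c(OC)c3)[C@@H](C)[C@@H]2C)cc1OC` — > 10000 nM
compound 2 `C/C=C/c1cc(OC)c(O[C@H](C)[C@H](O)c2ccc(OC)c(OC)c2)c(OC)c1` — > 10000 nM
compound 3 `COc1cc([C@@H]2O[C@@H](c3cc(OC)c(O)c(OC)c3)[C@H](CO[C@@H]3O[C@H](CO)[C@@H](O)[C@H](O)[C@H]3O)[C@H]2CO)cc(OC)c1O` — > 10000 nM

In this assay compound 1 returns only a limit, > 10000 nM, not a number. Compound 2 likewise reaches only a limit, > 10000 nM. Compound 3 too gives a limit, > 10000 nM. Compound 1 therefore stands nowhere distinct on the numbers shown: every value sits at the limit of > 10000 nM in this assay, at which 3 of the 3 values shown sit, and no step between measured compounds can be drawn from them.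

Compound 4 `COc1ccc([C@H]2O[C@H](c3cc(OC)c(OC)c(OC)c3)[C@@H](C)[C@H]2C)cc1OC` is the next to be measured. It differs from compound 1 in one place:

the two compounds have the same atoms and bonds and differ only in configuration as drawn: 1 of 4 stereo elements differ; a stereocentre at a saturated ring carbon is drawn S in compound 1 and R in compound 4

Among the measured compounds shown here, no measured pair shows what such a change in configuration does in this assay. With compound 1 already at the limit, the step is expected to be none beyond the scatter, or at most a shift that still ends at the limit; the expected step is a step that the limit leaves unreadable from compound 1 to compound 4. Compound 4 is accordingly estimated at 20000 nM, with a range from 8000 nM to 50000 nM, and most probably reported again only as a limit.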

Compound 4, half-maximal inhibitory concentration: 6920 nM
Estimate against measurement, compound 4: 2.9-fold (0.46 log units) above; the whole stated range lies above it.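

In this assay, among the compounds shown here, compound 4 gives a measured number (6920 nM), the only one among the values shown that is not a limit. Compound 1 gives only a limit (> 10000 nM). Inverting this one saturated ring carbon from S to R gives an at least 1.4-fold lower number from compound 1 to compound 4 (0.15 log units; that floor lies within the scatter) and so marks the configuration at this stereocentre as the only structural variable in this pair, with the floor of the step not separable from the scatter: the fact that compounds 1 and 4 differ only in the configuration as drawn

The true size of the step stays open, since compound 1 has no number to set against compound 4: the limit of > 10000 nM in this assay, at which 3 of the 4 values shown sit.

Also open, going by these compounds, is whether an amine or a carboxylic acid at this saturated ring carbon would give a number in this assay, and what inverting the other stereo elements would do.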